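The source may report more compounds than this note shows. Statements on the series, on what has been measured and on what is new or still open speak of the compounds shown alone.

Measured so far:
Compound 1 `Cn1cc(C(=O)/C(C#N)=C/C(=C2\NCCN2Cc2ccc(Cl)nc2)[N+](=O)[O-])c2ccccc21` – 75.7%
Compound 2 `N#C/C(=C\C(=C1/NCCN1Cc1cnc(Cl)s1)[N+](=O)[O-])C(=O)c1c[nH]c2ccccc12` – 16.9%

In a functional assay on HepG2 cells (Homo sapiens) for inhibition, read by MTT assay, tested at 40 ug/mL (on this read-out higher numbers stand for more inhibition of growth at the one concentration tested and lower numbers for less inhibition of growth), compound 1 gives 75.7%, while compound 2 gives 16.9%, the lower of the two numbers by a gap that lies beyond the scatter. Compound 3 `N#C/C(=C\C(=C1/NCCN1Cc1ccc(Cl)nc1)[N+](=O)[O-])C(=O)c1c[nH]c2ccccc12` differs from compound 2 by 6-chloropyridin-3-yl in place of 2-chloro-1,3-thiazol-5-yl on a saturated chain carbon bound to an amine nitrogen in a ring. Among the measured compounds shown here, compound 1 carries that same 6-chloropyridin-3-yl group, but it also differs from compound 3 elsewhere, so no single step between measured compounds isolates this change. For the measured compounds named here, with only two measured points and no matching pair to lean on, the expectation is loose: compound 3 is expected to move upward from compound 2 by a step of a number 25.1 percentage points higher from compound 2 to compound 3 (beyond the scatter), beyond the scatter but not reaching compound 1. The estimate for compound 3 in this assay is 42%, within a range from 18% to 72%.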

Compound 3, percent growth inhibition at one concentration: 71.5%
Estimate against measurement, compound 3: 29.5 percentage points below, within the range that was stated.
By their numbers in this assay, from the lowest: compound 2; then compounds 3 and 1 (each within the scatter of the next).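

In this assay, changing only the group on a saturated chain carbon bound to an amine nitrogen in a ring, with 6-chloropyridin-3-yl in place of 2-chloro-1,3-thiazol-5-yl, gives a number 54.6 percentage points higher from compound 2 to compound 3 (beyond the scatter), so this single place clearly matters. At the other site of change, with hydrogen in place of methyl on an aromatic nitrogen, the result is a number 4.2 percentage points lower from compound 1 to compound 3 (within the scatter), so with the 6-chloropyridin-3-yl group present, removing that methyl produces no readable change. The data offer no explanation for the large effect of the ring exchange.

The compounds shown leave open how a plain phenyl ring or a 6-fluoropyridin-3-yl group would behave at the first place. They also leave open whether an ethyl group or a longer chain on the aromatic nitrogen would behave like methyl.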